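A few compounds are considered here, and "the series" means these few. Any claim that something is new, unique, unknown or untested is made for them only; others in the source may bear on it.

Working notes on the series.

For the measured compounds named here, compound 2 `CC(C)(C)CC[C@H](c1ccc(C(=O)NCCC2=NNNN2)cc1)N1C(=O)C(c2cc(Cl)cc(Cl)c2)=N[C@]12CC[C@@H](C(C)(C)C)CC2` stands lowest of the two numbers so far in a functional assay on CHO cells for antagonist activity at Glucagon receptor (Homo sapiens), read by cAMP accumulation, with stated times of 30 min and 45 min; a higher number here means a weaker inhibitor, a lower number a stronger inhibitor: compound 2 gives 890 nM, while compound 1 `CC(C)(C)CC[C@H](c1ccc(C(=O)NCCS(=O)(=O)O)cc1)N1C(=O)C(c2cc(Cl)cc(Cl)c2)=N[C@]12CC[C@@H](C(C)(C)C)CC2` gives 8500 nM, the step being a 9.6-fold lower number from compound 1 to compound 2 (0.98 log units; beyond the scatter). Compound 3 `CC(C)(C)CC[C@H](c1ccc(C(=O)NCC(=O)O)cc1)N1C(=O)C(c2cc(Cl)cc(Cl)c2)=N[C@]12CC[C@@H](C(C)(C)C)CC2` is the next variation on the same chain; it differs from compound 2 by a group of 3 heavy atoms (1 carbon, 2 oxygen; no ring) in place of a group of 6 heavy atoms (2 carbon, 4 nitrogen; one five-membered non-aromatic ring with 4 hetero atoms), on a saturated chain carbon bound to an amide-type nitrogen. Going by the values given here, only one measured step bears on this change, that from compound 1 to compound 2, and it replaced the chain terminus in the other direction, so it is a loose guide at best; its size, a 9.6-fold lower number from compound 1 to compound 2 (0.98 log units; beyond the scatter), shows that this terminus can move the number well beyond the scatter. Among the compounds with values here, with no direct precedent for a carboxy terminus, the expectation for compound 3 in this assay is a number raised toward that of compound 1, a step of a 3.4-fold higher number from compound 2 to compound 3 (0.53 log units; beyond the scatter). Compound 3 is thus estimated at 3000 nM, within 900 nM to 10000 nM.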

Compound 3, half-maximal inhibitory concentration: 2700 nM
Compound 3: middle estimate off by 1.1-fold (0.05 log units), on the high side, within the range that was stated.
By their numbers in this assay, from the lowest: compound 2; then compound 3; then compound 1.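

In this assay, carboxy on a saturated chain carbon bound to an amide-type nitrogen places compound 3 between the other two compounds, a 3.1-fold lower number from compound 1 to compound 3 (0.50 log units; beyond the scatter) in place of sulfomethyl and a 3.0-fold higher number from compound 2 to compound 3 (0.48 log units; beyond the scatter) in place of the group with the five-membered non-aromatic ring. Both steps lie beyond the scatter, so this position now separates three terminal groups into a graded order rather than a single contrast. No measurement shown here accounts for that order.

Each step changes the length of the chain along with its terminal group, which leaves the contribution of each unresolved. A longer chain ending in carboxy would help separate the two, while an amine at this position remains an open case.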